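The source may report more compounds than this note shows. Statements on the series, on what has been measured and on what is new or still open speak of the compounds shown alone.

Measured so far in an ADME assay on MT4 cells (Homo sapiens) for cytotoxicity, read by MTT assay, with a stated time of 4 days; a lower number here means that less compound is tolerated, a higher number that more compound is tolerated:
Compound 1 `Cc1ccc(NC(=O)CS(=O)(=O)c2nccc(Oc3c(C)cc(C#N)cc3C)n2)cc1C` gives 13900 nM.
Compound 2 `COc1ccc(NC(=O)CS(=O)(=O)c2nccc(Oc3c(C)cc(C#N)cc3C)n2)cc1` gives 5110 nM.
Compound 3 `Cc1cc(C#N)cc(C)c1Oc1ccnc(S(=O)(=O)CC(=O)Nc2ccc(C#N)cc2)n1` is reported only as a limit, >= 6010 nM.

Compound 3 thus stands at a limit of this assay rather than at a number; this is the situation described by the limit of >= 6010 nM in this assay, at which 1 of the 3 values shown sits. Compound 4 `Cc1cc(C#N)cc(C)c1Oc1ccnc(S(=O)(=O)CC(=O)Nc2cccc([N+](=O)[O-])c2)n1` has not yet been measured and differs from compound 3 by 3-nitrophenyl in place of 4-cyanophenyl on an amide-type nitrogen. Every measured step in the series changes the aryl group on that same amide-type nitrogen: a 2.7-fold lower number from compound 1 to compound 2 (0.43 log units; beyond the scatter), whereas an at least 1.1-fold higher number from compound 2 to compound 3 (0.07 log units; that floor lies within the scatter) and a step that the limit leaves unreadable from compound 1 to compound 3. Going by the values given here, the one readable step is modest, and no aryl swap has moved the number far, so the change from compound 3 to compound 4 is not expected to exceed the scatter; the expected step is a step that the limit leaves unreadable from compound 3 to compound 4. Compound 4 is therefore estimated at 8000 nM, in the range 3000 nM to 20000 nM, with a real chance that compound 4 again returns only a limit.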

Compound 4, half-maximal cytotoxic concentration: 23600 nM
Compound 4: middle estimate off by 3.0-fold (0.47 log units), on the low side; measured number above the stated range.
By their numbers in this assay, from the lowest: compound 2; then compounds 1 and 4 (each within the scatter of the next).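

In this assay, a ring bearing a nitro group on the amide-type nitrogen is the first aryl change shown to sit beyond the scatter from compound 2 while carrying a number rather than a limit: a 4.6-fold higher number from compound 2 to compound 4 (0.66 log units; beyond the scatter). Against the 3,4-dimethylphenyl group, the same swap gives a 1.7-fold higher number from compound 1 to compound 4 (0.23 log units; within the scatter), so compounds 1 and 4 are not separated and only compound 2 stands apart from them. The step from compound 3 cannot be read, because compound 3 stands at a limit: the limit of >= 6010 nM in this assay, at which 1 of the 4 values shown sits.

Going by these compounds, whether the 3-nitrophenyl or the 4-cyanophenyl group is better tolerated stays open. Also open is how this position responds to a ring carrying an amine or a carboxylic acid, since all the groups shown are neutral aryl rings.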